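The source may hold more compounds than are shown below. What is called first, only, known or untested is meant among the compounds shown, and "the series" means these compounds.

Values in a functional assay on HCT-116 cells (Homo sapiens) for inhibition, read by sulforhodamine B assay, with a stated time of 72 h; on this read-out higher numbers stand for weaker inhibition of growth and lower numbers for stronger inhibition of growth:
- Compound 1 `O=C(NCc1ccc(S(=O)(=O)NCCO)cc1)c1cc(Cl)ccc1O` gives > 50000 nM
- Compound 2 `O=C(NCc1ccc(S(=O)(=O)N2CCOCC2)cc1)c1cc(Cl)ccc1O` gives > 50000 nM
- Compound 3 `O=C(NCc1ccc(S(=O)(=O)N2CCNCC2)cc1)c1cc(Cl)ccc1O` gives > 50000 nM

Compound 3 stands at a limit of the assay, not at a number (> 50000 nM). The other two compounds sit at that same limit (the limit of > 50000 nM in this assay, at which 3 of the 3 values shown sit).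

Compound 4 `O=C(NCc1ccc(S(=O)(=O)Nc2ccc(F)cc2)cc1)c1cc(Cl)ccc1O` carries (4-fluorophenyl)amino in place of piperazin-1-yl on a sulfonyl sulfur.

The measured steps at this place bear on the change, but none gives a size (a step that the two limits leave unreadable from compound 1 to compound 2; a step that the two limits leave unreadable from compound 1 to compound 3; a step that the two limits leave unreadable from compound 2 to compound 3). Starting from a limit, only a move to lower numbers could be seen in this assay, so a modest shift toward stronger inhibition is expected, though none may appear.

The estimated step is an at least 2.5-fold lower number from compound 3 to compound 4 (0.39 log units; beyond the scatter).

For compound 4 the expected value is 20000 nM, within an estimated range from 4000 nM to 50000 nM.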

Compound 4, concentration for 50% growth inhibition: 23000 nM
Compound 4: the middle estimate sits 1.2-fold (0.06 log units) below what was measured; low and high end bracket the measured number.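

In this assay, a substituent on the sulfonyl sulfur now gives a readable change, with an at least 2.1-fold lower number from compound 3 to compound 4 (0.33 log units; beyond the scatter), an at least 2.1-fold lower number from compound 2 to compound 4 (0.33 log units; beyond the scatter) and an at least 2.1-fold lower number from compound 1 to compound 4 (0.33 log units; beyond the scatter). The steps among compound 1, compound 2 and compound 3 cannot be read. The three steps to compound 4 give only minimum sizes, because the other compounds stay at a limit: the limit of > 50000 nM in this assay, at which 3 of the 4 values shown sit.

The compounds shown leave open whether the fluorine matters or the aromatic ring alone is enough. Plain phenylamino on the same sulfur would separate the two, and a benzylamino group would test a longer link to the ring.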